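From pyrrolidin-2-yl to 4-chlorophenyl on the shared core

The source may hold more compounds than are shown below. What is called first, only, known or untested is meant among the compounds shown, and "the series" means these compounds.

- Compound 1 `COc1ccc(-c2noc(C3CCCN3)n2)cc1OC1CCCC1`: 19500 nM
- Compound 2 `COc1ccc(-c2noc(Cc3c[nH]c4ccccc34)n2)cc1OC1CCCC1`: 9560 nM
- Compound 3 `COc1cc(-c2noc(-c3ccncc3)n2)ccc1OCc1ccccc1`: > 1000000 nM (a limit)

In a functional assay on MIA PaCa-2 cells (Homo sapiens) for antiproliferative activity, read by MTT assay, with a stated time of 24 h (on this read-out lower numbers stand for stronger inhibition and higher numbers for weaker inhibition), compound 1 gives 19500 nM, the higher of the two true numbers available. Compound 2 gives 9560 nM, and the gap between these two lies beyond the usual scatter. Compound 3 is recorded only as > 1000000 nM, which is a limit of the assay and not a number.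

Compound 4 `COc1ccc(-c2noc(-c3ccc(Cl)cc3)n2)cc1OC1CCCC1`, not yet measured, keeps the core of compound 1 and carries 4-chlorophenyl in place of pyrrolidin-2-yl on an aromatic carbon. Among the measured compounds shown here, no measured pair isolates this change, so the expectation is loose. Compound 2 carries a different group on that same carbon, and its value of 9560 nM is the nearest guide. In this assay, no step beyond the scatter is expected, with any shift tending towards a lower number. The estimate is a 1.3-fold lower number from compound 1 to compound 4 (0.11 log units; within the scatter). Compound 4 is expected at 15000 nM, with an estimated range of 3000 nM to 80000 nM.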

Compound 4, half-maximal inhibitory concentration: 740 nM
For compound 4 the middle estimate is 20-fold (1.31 log units) above the measured one; measured number outside the range, below it.
By their numbers in this assay, from the lowest: compound 4; then compound 2; then compound 1. At a limit, above all of these: compound 3.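

In this assay, among the compounds shown here, placing 4-chlorophenyl in place of pyrrolidin-2-yl gives a 26-fold lower number from compound 1 to compound 4 (1.42 log units; beyond the scatter) and so shows that this aromatic carbon can carry a large shift, one not foreseeable from the earlier compounds. Before this result, the only numbers for groups on this carbon were those of compound 1 at 19500 nM and compound 2 at 9560 nM and neither carried an aromatic ring joined directly to it. Nothing measured here accounts for the size of this step.

What the compounds shown leave open is whether the chlorine is needed, or whether a plain phenyl or a 4-fluorophenyl on this carbon would read the same. Also open, as far as these compounds go, is how an amine or a carboxylic acid on that phenyl ring would read.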